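This account rests on a few compounds, and the source may have more. Where it says the series, first, only, none or still open, it means among the compounds named here.

Measured so far in a functional assay (brain) with Rattus norvegicus as the target; a higher number here means a weaker inhibitor, a lower number a stronger inhibitor:
compound 1 `COC(=O)[C@@H]1CN(C)CC[C@@H]1c1ccc2ccccc2c1` gives 23 nM;
compound 2 `COC(=O)[C@@H]1CN(C)CC[C@H]1c1ccc2ccccc2c1` gives 94 nM;
compound 3 `COC(=O)[C@H]1CN(C)CC[C@H]1c1ccc2ccccc2c1` gives 293 nM.

Compound 2 holds the middle number of the three. The steps of a 4.1-fold higher number from compound 1 to compound 2 (0.61 log units; beyond the scatter) and a 3.1-fold higher number from compound 2 to compound 3 (0.49 log units; beyond the scatter) both lie beyond the scatter, and so does a 13-fold higher number from compound 1 to compound 3 (1.11 log units; beyond the scatter). All three compounds share one set of atoms and bonds and differ only in how the two ring stereocentres are drawn (the fact that compounds 1 and 2 differ only in the configuration as drawn, (the fact that compounds 1 and 3 differ only in the configuration as drawn), (the fact that compounds 2 and 3 differ only in the configuration as drawn)).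

Compound 4 `COC(=O)[C@@H]1CNCC[C@H]1c1ccc2ccccc2c1` differs from compound 2 in a single place: hydrogen in place of methyl on an amine nitrogen in a ring. Going by the values given here, none of the measured steps changes this amine nitrogen, so they offer no measured guide to this change. The step of a 1.3-fold lower number from compound 2 to compound 4 (0.13 log units; within the scatter) is therefore expected to stay within the scatter. Compound 4 is estimated at 70 nM, with a range from 25 nM to 250 nM.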

Compound 4, half-maximal inhibitory concentration: 97 nM
Compound 4: middle estimate off by 1.4-fold (0.14 log units), on the low side; the measured number falls inside the stated range.
By their numbers in this assay, from the lowest: compound 1; then compounds 2 and 4 (each within the scatter of the next); then compound 3.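

The step (a 1.0-fold higher number from compound 2 to compound 4 (0.01 log units; within the scatter)) shows that methyl and hydrogen on this amine nitrogen cannot be told apart by their numbers. Going by these compounds alone, the earlier compounds showed only that the configuration at the two ring stereocentres matters; this is the first sign that a change elsewhere on the shared core can leave the number within the scatter. The data at hand give no explanation for this result. Going by these compounds, whether this also holds with the configurations of compound 1 and compound 3 remains open. Also open, on these data alone, is what a longer chain, such as propyl or benzyl, would give on this nitrogen.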